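The source may report more compounds than this note shows. Statements on the series, on what has been measured and on what is new or still open speak of the compounds shown alone.

Measured so far in an ADME assay on L02 cells (Homo sapiens) for cytotoxicity, read by MTT assay; on this read-out lower numbers stand for stronger inhibition and higher numbers for weaker inhibition:
- compound 1 `COc1ccc(/C=C/C(=O)c2ccc(OC)c3c2OC(C)(C)C=C3)cc1O`: > 10000 nM
- compound 2 `COc1ccc(/C=C/C(=O)c2ccc(OC)c3c2OC(C)(C)C=C3)cc1OC(=O)CCl`: > 10000 nM
- compound 3 `COc1ccc(/C=C/C(=O)c2ccc(OC)c3c2OC(C)(C)C=C3)cc1OC(=O)C1CC1`: > 10000 nM

Compound 3 gives > 10000 nM, which is a limit of the assay and not a number. The other two entries are limits as well, so all three compounds sit at the limit of > 10000 nM in this assay, at which 3 of the 3 values shown sit. Nothing in these data ranks one above another.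

Compound 4 `COc1ccc(/C=C/C(=O)c2ccc(OC)c3c2OC(C)(C)C=C3)cc1OS(=O)(=O)c1ccc(C)cc1` carries (4-methylphenyl)sulfonyl in place of cyclopropylcarbonyl on an oxygen on an aromatic ring. The rest of the molecule stays the same.

Three measured steps change the group on this same oxygen. They are a step that the two limits leave unreadable from compound 1 to compound 2, a step that the two limits leave unreadable from compound 1 to compound 3 and a step that the two limits leave unreadable from compound 2 to compound 3. None has a size that can be read, so they give no sign that this oxygen's substituent moves the result in this assay. They also cannot rule out an effect, and the new group is larger than any tested so far. The expectation is therefore no step beyond the usual scatter, with the assay quite likely reporting only a limit again.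

The estimated step is a step that the limit leaves unreadable from compound 3 to compound 4.

Compound 4 is expected at about 20000 nM, with an estimated range from 10000 nM to 50000 nM.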

Compound 4, half-maximal inhibitory concentration: > 10000 nM
Compound 4 was reported as a limit; the forecaster's own chance of this, stated with the estimate: 85%; the middle value lies beyond the limit too.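

In this assay compound 4 gives > 10000 nM, which is a limit of the assay and not a number. No step among compound 1, compound 2, compound 3 and compound 4 can be read, since all four sit at the same limit: the limit of > 10000 nM in this assay, at which 4 of the 4 values shown sit.

The compounds shown leave open whether any group on this oxygen changes the result in this assay, and how far each compound lies beyond the limit.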